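Adding methoxycarbonyl to compound 2

This account rests on a few compounds, and the source may have more. Where it says the series, first, only, none or still open, it means among the compounds named here.

In a functional assay on MCF7 cells (Homo sapiens) for cytotoxicity, read by MTT assay, with a stated time of 24 h (on this read-out higher numbers stand for weaker inhibition and lower numbers for stronger inhibition), compound 2 `COC(=O)[C@@H](C)NC(=O)Cn1cc(C2=C(c3c[nH]c4ccccc34)C(=O)N(C)C2=O)c2ccccc21` gives 15300 nM and stands level with compound 3 `COC(=O)[C@H](NC(=O)Cn1cc(C2=C(c3c[nH]c4ccccc34)C(=O)N(C)C2=O)c2ccccc21)C(C)C` at 16000 nM within the scatter. Compound 1 `CC[C@H](C)[C@@H](NC(=O)Cn1cc(C2=C(c3c[nH]c4ccccc34)C(=O)N(C)C2=O)c2ccccc21)C(=O)OC` shows > 100000 nM as a limit and not a number. Compound 4 `COC(=O)C[C@@H](NC(=O)Cn1cc(C2=C(c3c[nH]c4ccccc34)C(=O)N(C)C2=O)c2ccccc21)C(=O)OC` differs from compound 2 by methoxycarbonyl in place of hydrogen on a saturated chain carbon, two bonds along the chain from an amide-type nitrogen and a carbonyl carbon and so carries methoxycarbonyl in place of hydrogen on a saturated chain carbon. Two measured steps alter this same chain: a 1.0-fold higher number from compound 2 to compound 3 (0.02 log units; within the scatter) stays within the scatter, while an at least 6.5-fold lower number from compound 1 to compound 2 (0.81 log units; beyond the scatter) lies beyond it. Neither step adds methoxycarbonyl, so the closer guide is the small step to compound 3. Only a 1.3-fold higher number from compound 2 to compound 4 (0.12 log units; within the scatter) is therefore expected in this assay and no shift beyond the scatter. Compound 4 is estimated at 20000 nM with 7000 nM to 60000 nM as its expected range.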

Compound 4, half-maximal inhibitory concentration: 25800 nM
Estimate against measurement, compound 4: 1.3-fold (0.11 log units) below; measured number inside the range.
By their numbers in this assay, from the lowest: compounds 2, 3 and 4 (each within the scatter of the next). At a limit, above all of these: compound 1.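

In this assay, going by these compounds alone, the first added group on this chain carbon, methoxycarbonyl in place of hydrogen, gives a 1.7-fold higher number from compound 2 to compound 4 (0.23 log units; within the scatter). (Methoxycarbonyl)methyl in place of isopropyl gives a 1.6-fold higher number from compound 3 to compound 4 (0.21 log units; within the scatter), so this larger group with its two hydrogen-bond acceptors leaves the number level with both smaller side chains. Compound 1 remains a limit and not a number, and an at least 3.8-fold lower number from compound 1 to compound 4 (0.58 log units; beyond the scatter) marks only a bound: the limit of > 100000 nM in this assay, at which 1 of the 4 values shown sits.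

Still open, on these data alone, is how a carboxylic acid in place of methoxycarbonyl would read here. As far as these compounds go, an amine or a longer chain carrying methoxycarbonyl at this carbon is equally open.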